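Methoxy to Methyl on the Aromatic Ring of Compound 1

The source may hold more compounds than are shown below. What is called first, only, known or untested is meant among the compounds shown, and "the series" means these compounds.

In a functional assay on MT4 cells (Homo sapiens) for antiproliferative activity, read by MTT assay, with a stated time of 96 h (on this read-out lower numbers stand for stronger inhibition and higher numbers for weaker inhibition), compound 1 (`COc1ccc(N2C(=O)NC3(CSC4=C3C(=O)c3ncccc3C4=O)C2=O)cc1`) gives 70 nM. This is the only number shown for it, and one further entry carries no single number. Compound 2 (`O=C1NC(=O)C2(CSC3=C2C(=O)c2ncccc2C3=O)N1`), which has no 4-methoxyphenyl group, gives 130 nM; 120 nM; 130 nM (3 entries), and its repeat measurements agree closely: the several entries of compound 2 in this assay, 130 nM; 120 nM; 130 nM (3 entries). The values of compound 1 and compound 2 lie within the usual scatter of each other.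

Compound 3 (`Cc1ccc(N2C(=O)NC3(CSC4=C3C(=O)c3ncccc3C4=O)C2=O)cc1`) keeps the core of compound 1 but has methyl in place of methoxy on an aromatic carbon, para to a large group: methyl in place of methoxy on an aromatic carbon. Within the data shown here, no measured pair shows this change directly. Since even compound 2 at 130 nM; 120 nM; 130 nM (3 entries) stays within the scatter of compound 1, no shift beyond the scatter is expected in this assay, in either direction. The expected step of a 1.2-fold higher number from compound 1 to compound 3 (0.08 log units; within the scatter) is therefore small. For compound 3 the estimated value is 85 nM, with an expected range from 35 nM to 210 nM.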

Compound 3, half-maximal inhibitory concentration: 27 nM
Compound 3: the middle estimate sits 3.1-fold (0.50 log units) above what was measured; measured number below the stated range.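

In this assay, putting methyl in place of methoxy gives a 2.6-fold lower number from compound 1 to compound 3 (0.41 log units; beyond the scatter), the only step shown here and one that stands clear of the usual scatter. This position on the aromatic ring is therefore not indifferent to what it carries: a change of a single small group, with one oxygen lost, moves the number toward stronger inhibition. Repeat measurements can agree closely in this assay, which supports reading the step as real, although compound 1 has only one number to go on: the several entries of compound 2 in this assay, 130 nM; 120 nM; 130 nM (3 entries)

Why methyl does better than methoxy cannot be told from one pair, since heavy-atom count and hydrogen-bond acceptor count change together. Also open, going by these compounds, is how chlorine, an amine or a longer chain such as ethyl would fare on the same aromatic carbon.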